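The compounds below may be only part of what the source reports. "The series", "measured", "known", "first", "only" and "open" are said of these compounds alone.

Measured so far in an ADME assay on microsomes from liver (Rattus norvegicus) for metabolic stability, read by LC-MS, using NADPH, at 37 degrees C; on this read-out higher numbers stand for a longer-lived compound and lower numbers for a shorter-lived compound:

compound 1 `Cc1cc(C)c(-c2nc(CN3CCC(C(=O)NCCCN4C[C@H](C)C[C@H](C)C4)CC3)c(C)o2)c(C)c1`: > 0.5 h
compound 2 `Cc1ccccc1-c1nc(CN2CCC(C(=O)NCCCN3CCC(C)(C)CC3)CC2)c(C)o1`: > 0.5 h
compound 3 `Cc1oc(-c2c(Cl)cccc2Cl)nc1CN1CCC(C(=O)NCCCN2C[C@H](C)C[C@H](C)C2)CC1`: 0.0483 h

The value for compound 2 is a limit of this assay, not a number. The value for compound 1 is likewise a limit. Two of the three values therefore sit at the same limit (the limit of > 0.5 h in this assay, at which 2 of the 3 values shown sit); only compound 3 gives a number. Going by the values given here, the one step that can be read is an at least 10-fold lower number from compound 1 to compound 3 (1.01 log units; beyond the scatter), a change on the aryl part of the core that is far from the amine end.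

Compound 4 `Cc1ccccc1-c1nc(CN2CCC(C(=O)NCCCCN3C[C@H](C)C[C@H](C)C3)CC2)c(C)o1` differs from compound 2 as follows.

(3,5-dimethylpiperidin-1-yl)methyl in place of 4,4-dimethylpiperidin-1-yl on a saturated chain carbon, three bonds along the chain from an amide-type nitrogen

Among the compounds with values here, no measured step covers this change; the step from compound 1 to compound 3 concerns the aryl group and does not bear on the amine end. What the data show is that compound 1, which carries the 3,5-dimethylpiperidinyl amine, and compound 2, with the 4,4-dimethylpiperidinyl amine, both stop at the same limit. Thus no step beyond the scatter is expected, a step that the limit leaves unreadable from compound 2 to compound 4, and the estimate for compound 4 is 0.7 h, ranging from 0.3 h to 1.6 h, most likely again reported as a limit.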

Compound 4, half-life: 0.2 h
For compound 4 the middle estimate is 3.5-fold (0.54 log units) above the measured one; the measured number lies below the stated range.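

In this assay the amine end now gives a readable change, with compound 4 at 0.2 h as a number and not a limit, and the step lies beyond the scatter: an at least 2.5-fold lower number from compound 2 to compound 4 (0.39 log units; beyond the scatter). The value of compound 2 is a limit, so the size of this step is a bound only: the limit of > 0.5 h in this assay, at which 2 of the 4 values shown sit. The earlier step concerned the aryl group alone, whereas this one shows that the number also moves when 2-(4,4-dimethylpiperidin-1-yl)ethyl gives way to 3-(3,5-dimethylpiperidin-1-yl)propyl.

On these data alone, the chain length and the placing of the methyl groups change together here, so which of the two carries the step stays open. Also open, as far as these compounds go, is how this end behaves with a morpholine or an unsubstituted piperidine in place of the dimethylpiperidines.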